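The source may report more compounds than this note shows. Statements on the series, on what has been measured and on what is new or still open speak of the compounds shown alone.

Three compounds share one core and differ at two points: the group on the ring nitrogen and the amine attached to the core. Compound 1 `CC(C)CCn1ccc(N(C)Cc2ccccc2)c(C#N)c1=O` carries a benzyl methylamine and, in a functional assay on CHO cells for positive allosteric modulation of metabotropic glutamate receptor 2 (Homo sapiens), with a stated time of 30 min (on this read-out lower numbers stand for an effect already at smaller amounts and higher numbers for an effect only at larger amounts of compound), compound 1 gives 10700 nM. Compound 2 `CC(C)CCn1ccc(N2CCC(c3ccccc3)CC2)c(C#N)c1=O` carries a phenylpiperidine instead and, in this assay, compound 2 gives 102 nM. Compound 3 `CCCCn1ccc(N2CCC(c3ccccc3)CC2)c(C#N)c1=O` keeps that phenylpiperidine and shortens the chain on the ring nitrogen; in this assay compound 3 gives 95 nM, the lowest of the three numbers, with compound 2 close by and compound 1 far off. Going by the values given here, the one step between neighbours, a 1.1-fold lower number from compound 2 to compound 3 (0.03 log units; within the scatter), shows that trimming the chain on the ring nitrogen changed little.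

Compound 4 `CC(C)Cn1ccc(N2CCC(c3ccccc3)CC2)c(C#N)c1=O` differs from compound 3 by isopropyl in place of propyl on a saturated chain carbon bound to an aromatic nitrogen. Among the compounds with values here, the only step that bears on it is the change of chain shape on the same nitrogen, which stayed within the scatter from compound 2 to compound 3. No step beyond the scatter is therefore expected, and the estimated change is a 1.1-fold higher number from compound 3 to compound 4 (0.02 log units; within the scatter). Compound 4 is expected to give about 100 nM, between 45 nM and 220 nM.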

Compound 4, half-maximal effective concentration: 282 nM
Estimate against measurement, compound 4: 2.8-fold (0.45 log units) below; measured number above the stated range.
By their numbers in this assay, from the lowest: compounds 3 and 2 (each within the scatter of the next); then compound 4; then compound 1.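

The chain on the ring nitrogen turns out not to be indifferent: in this assay replacing butyl with isobutyl, which keeps the same atoms but joins them differently, gives a 3.0-fold higher number from compound 3 to compound 4 (0.47 log units; beyond the scatter) and so a modest step that the earlier chain change did not show. Going to isobutyl from the longer chain gives a 2.8-fold higher number from compound 2 to compound 4 (0.44 log units; beyond the scatter) and so a step of similar size, which shows that at this position the arrangement of the chain counts, not only its number of atoms. Nothing available explains this difference.

On these data alone, whether a shorter chain such as ethyl or a longer one such as hexyl would stay near compound 3 or fall nearer compound 4 remains open. So does the effect of a chain ending in an amine or a carboxylic acid.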